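The source may hold more compounds than are shown below. What is called first, only, known or untested is meant among the compounds shown, and "the series" means these compounds.

Compound 1 `CN(C)C(=O)c1cc2cnc(Nc3ccc(C(=O)NCCCCN=C=S)cc3)nc2n1C1CCCC1`: 55.2%
Compound 2 `CN(C)C(=O)c1cc2cnc(Nc3ccc(C(=O)NCCCN=C=S)cc3F)nc2n1C1CCCC1`: 9.27%

In a functional assay on NCI-H1299 cells (Homo sapiens) for inhibition, read by CCK-8 assay, with a stated time of 72 h, tested at 1 uM (a higher number here means a stronger effect of the compound at the concentration tested, a lower number a weaker effect), compound 2 gives 9.27%, the lowest of the two numbers. For the measured compounds named here, compound 1 stands higher by a margin beyond the scatter, but the two differ in more than one place, so their values show only that one compound acts more strongly than the other, not which change carries it.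

Compound 3 `CN(C)C(=O)c1cc2cnc(Nc3ccc(C(=O)NCCCCN=C=S)cc3F)nc2n1C1CCCC1` has not yet been measured in this assay. It differs from compound 2 in one place: a group of 4 heavy atoms (2 carbon, 1 nitrogen, 1 sulfur; no ring) in place of a group of 3 heavy atoms (1 carbon, 1 nitrogen, 1 sulfur; no ring), on a saturated chain carbon, three bonds along the chain from an amide-type nitrogen. Going by the values given here, no single-change step between measured compounds is known, so the size of this step is open. A rise is nevertheless expected, because in this assay compound 1, which carries this same longer chain, gives 55.2%. Compound 3 is therefore estimated at about 32%, within a range from 10% to 55%. That expectation amounts to an upward step a number 22.7 percentage points higher from compound 2 to compound 3 (beyond the scatter), likely beyond the scatter.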

Compound 3, a percentage reported as inhibition, at one concentration (the size of the read-out at that concentration, not a potency): 28.7%
For compound 3 the middle estimate is 3.3 percentage points above the measured one; the measured number falls inside the stated range.
By their numbers in this assay, from the lowest: compound 2; then compound 3; then compound 1.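

In this assay, the group of 4 heavy atoms in place of the group of 3 heavy atoms, on a saturated chain carbon, three bonds along the chain from an amide-type nitrogen, gives a number 19.4 percentage points higher from compound 2 to compound 3 (beyond the scatter), so the longer chain now has a clean single-change reading, with the fluoro present in both compounds. Compound 3 also isolates the other change: with the longer chain held fixed, fluoro in place of hydrogen on an aromatic carbon gives a number 26.5 percentage points lower from compound 1 to compound 3 (beyond the scatter), so the fluoro compound acts more weakly at the concentration tested. No measurement at hand explains either step.

The compounds shown leave open whether fluoro in place of hydrogen has a similar effect on the shorter chain of compound 2, and whether a still longer chain would raise the number further. Also open, as far as these compounds go, is how a chloro or methoxy group on that aromatic carbon would compare with fluoro.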